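The source may report more compounds than this note shows. Statements on the series, on what has been measured and on what is new or still open speak of the compounds shown alone.

Measured compounds:
Compound 1, `COc1cc2cc(Oc3ccc(NC(=O)Nc4cccc(C(F)(F)F)c4)cc3)c(C)nc2cc1OC`: 6020 nM
Compound 2, `COc1cc2cc(Oc3ccc(NC(=O)Nc4ccc(Cl)c(C(F)(F)F)c4)cc3)c(C)nc2cc1OC`: 3570 nM

In a functional assay on NCI-H460 cells (Homo sapiens) for inhibition, read by sulforhodamine B assay, with a stated time of 48 h (a higher number here means a weaker inhibitor of growth, a lower number a stronger inhibitor of growth), compound 2 gives the lower of the two numbers, with compound 1 the nearest, and the gap between them, a 1.7-fold lower number from compound 1 to compound 2 (0.23 log units; within the scatter), is within the scatter. Compound 3, `COc1cc2cc(Oc3ccc(NC(=O)Nc4ccc(Cl)c(Cl)c4)cc3)c(C)nc2cc1OC`, has not been measured. It differs from compound 2 by chloro in place of trifluoromethyl on an aromatic carbon. Among the measured compounds shown here, only one measured step is available, and it concerns a different change: chloro in place of hydrogen, a 1.7-fold lower number from compound 1 to compound 2 (0.23 log units; within the scatter), which did not move the number beyond the scatter. For the measured compounds named here, no measured step swaps trifluoromethyl for chloro, so there is no direct guide for this exchange. Going by the values given here, on the single small step available, the number for compound 3 is expected to stay close to that of compound 2, with a step of a 1.1-fold higher number from compound 2 to compound 3 (0.05 log units; within the scatter) that is not expected to exceed the scatter. Compound 3 is therefore estimated at 4000 nM, with a range from 1500 nM to 12000 nM.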

Compound 3, concentration for total growth inhibition: 10100 nM
For compound 3 the middle estimate is 2.5-fold (0.40 log units) below the measured one, within the range that was stated.
By their numbers in this assay, from the lowest: compounds 2, 1 and 3 (each within the scatter of the next, the first and the last beyond it).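

In this assay, among the compounds shown here, the exchange of trifluoromethyl for chloro, ortho to a chloro group, gives a 2.8-fold higher number from compound 2 to compound 3 (0.45 log units; beyond the scatter) and is the only step among the compounds so far between two compounds that differ in one place to lie beyond the scatter, so this position does respond to the group it carries. The wider change to 3,4-dichlorophenyl in place of 3-(trifluoromethyl)phenyl on the amide-type nitrogen gives a 1.7-fold higher number from compound 1 to compound 3 (0.22 log units; within the scatter) and stays within the scatter, so compound 1 cannot be set apart from compound 3. Nothing at hand bears on the reason for the step from trifluoromethyl to chloro. The compounds shown leave open how a methoxy group, a nitrile or a fluoro group would compare at this position. They also leave open whether the step would hold with hydrogen in place of the chloro group that compound 2 and compound 3 share.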